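Swapping a methylpyridine for a hydroxymethylphenyl: lipophilicity

The source may report more compounds than this note shows. Statements on the series, on what has been measured and on what is new or still open speak of the compounds shown alone.

Two compounds of this series have a measured lipophilicity. In a physicochemical assay for lipophilicity, read by HPLC, at pH 7.5 (on this read-out lower numbers stand for lower lipophilicity and higher numbers for higher lipophilicity), compound 1 `N#Cc1c(-c2ccc(Br)cc2)nc2cnccc2c1NCC(N)=O` gives 1.9. Compound 2 `CC[C@@H](Nc1c(C#N)c(-c2ccc(-c3cnccc3C)cc2)nc2cnccc12)C(N)=O` gives 2 in this assay, the higher of the two numbers, with compound 1 only a small distance lower, a gap that lies within the scatter of the measurement.

Compound 3 `CC[C@@H](Nc1c(C#N)c(-c2ccc(-c3ccccc3CO)cc2)nc2cnccc12)C(N)=O` has not yet been measured. It differs from compound 2 in one place, on an aromatic carbon of the shared core's biaryl ring: 2-(hydroxymethyl)phenyl in place of 4-methylpyridin-3-yl on an aromatic carbon. Within the data shown here, no measured pair in this set shows the effect of such a swap, so the expectation rests on the two numbers available and on the nature of the exchange, one small heteroaromatic ring leaving and a carbon ring carrying a hydroxyl group entering.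

The step expected from compound 2 to compound 3 in this assay is a number 0.10 log units higher from compound 2 to compound 3 (within the scatter), a change no larger than the scatter. For compound 3 the estimated value in this assay is therefore 2.1, with a range from 1.6 to 2.6.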

Compound 3, distribution coefficient: 2.1
For compound 3 middle estimate and measured number coincide at the digits printed, within the range that was stated.
By their numbers in this assay, from the lowest: compounds 1, 2 and 3 (each within the scatter of the next).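

In this assay, putting 2-(hydroxymethyl)phenyl in place of 4-methylpyridin-3-yl on this aromatic carbon gives a number 0.10 log units higher from compound 2 to compound 3 (within the scatter) and so leaves the two compounds indistinguishable on this read-out. Among these compounds, this is the only measured pair here that differs in one place, and it shows that a ring of carbon only, carrying a hydrogen-bond donor, can replace a ring with one hetero atom without a step beyond the scatter. Nothing measured here explains why the two numbers lie so close.

One pair at one place leaves open whether an amine or a carboxylic acid at this position would also stay this close to compound 2. The pair also does not separate the exchange of rings from the hydroxymethyl group itself, a question on which a plain phenyl group would bear.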